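This account rests on a few compounds, and the source may have more. Where it says the series, first, only, none or still open, it means among the compounds named here.

Measured in an assay on isolated protein for inhibition of Ca2+/calmodulin-dependent protein kinase II (CaM kinase II) (Rattus norvegicus), tested at 30 uM; on this read-out lower numbers stand for less inhibition and higher numbers for more inhibition at the one concentration tested (going by the name of the read-out):
compound 1 `Cn1cnc2c(Nc3ccccc3)ncnc21` gives 0%;
compound 2 `Cn1cnc2c(Nc3ccc(F)cc3)ncnc21` gives 8%;
compound 3 `Cn1c(-c2ccc(S(C)(=O)=O)cc2)nc2c(Sc3ccccc3)ncnc21` gives 8%.

Among the compounds with values here, the only one-place step among the measured compounds is a number 8 percentage points higher from compound 1 to compound 2 (within the scatter), which goes with the change (fluoro in place of hydrogen on an aromatic carbon). Compound 3 stands level with compound 2 at the digits reported, and its difference from compound 1 lies in the core, which is not broken down here. Compound 4 `Cn1c(-c2ccc(S(C)(=O)=O)cc2)nc2c(Sc3ccc(F)cc3)ncnc21` carries the same change relative to compound 3, (fluoro in place of hydrogen on an aromatic carbon), made this time on the core of compound 3. Because the earlier step of a number 8 percentage points higher from compound 1 to compound 2 (within the scatter) stayed within the scatter, the step from compound 3 to compound 4 is expected to be similarly small, a number 4 percentage points higher from compound 3 to compound 4 (within the scatter). Compound 4 is therefore estimated at 12% in this assay, with a likely range from 0% to 25%.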

Compound 4, a percentage reported as inhibition, at one concentration (the size of the read-out at that concentration, not a potency): 0%
Compound 4: the middle estimate sits 12 percentage points above what was measured; the measured number falls inside the stated range.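

In this assay, the fluoro change on the core of compound 3 gives a number 8 percentage points lower from compound 3 to compound 4 (within the scatter). Set beside the earlier step on the core of compound 1, the two steps run in opposite directions and do not match: the same change on two cores in this assay, a number 8 percentage points higher (within the scatter) from compound 1 to compound 2 and a number 8 percentage points lower (within the scatter) from compound 3 to compound 4, 16 percentage points apart, beyond the scatter of two such steps Each step alone stays within the scatter, so this shows only that the size of the fluoro step cannot simply be carried from one core to the other; it does not show that fluoro reliably raises or lowers inhibition on either core.

The compounds shown leave open whether an amine or a carboxylic acid in place of the fluoro would give clearer inhibition on either core. They also leave open which of the differences between the two cores goes with the gap between the steps.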